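Methoxy onto the phenyl of a pyrazoline series

The compounds below may be only part of what the source reports. "The series", "measured", "known", "first", "only" and "open" are said of these compounds alone.

Compound 1 `Fc1ccc(C2CC(c3ccccc3)=NN2c2ccc(-c3ccccc3)nn2)cc1` gives 10000 nM in a functional assay on Caco-2 cells (Homo sapiens) for antiproliferative activity, read by MTT assay, with a stated time of 24 h (a lower number here means a stronger inhibitor, a higher number a weaker inhibitor), the lowest of the two numbers recorded so far. Its nearest neighbour is compound 2 `FC(F)(F)c1ccc(C2CC(c3ccccc3)=NN2c2ccc(-c3ccccc3)nn2)cc1`, which in this assay gives 50000 nM; the step of a 5.0-fold higher number from compound 1 to compound 2 (0.70 log units; beyond the scatter) is the only measured one, and it arises from trifluoromethyl in place of fluoro on an aromatic carbon. Compound 3 `COc1ccc(C2=NN(c3ccc(-c4ccccc4)nn3)C(c3ccc(F)cc3)C2)cc1` differs from compound 1 by methoxy in place of hydrogen on an aromatic carbon, a change that turns phenyl into 4-methoxyphenyl while the fluoro of compound 1 stays where it is. Within the data shown here, no measured step touches a methoxy group, and the one step that exists concerns a different substitution, so it offers only a loose guide to the size a ring substitution can produce. A step of no change at the digits printed from compound 1 to compound 3 (within the scatter) is therefore expected, within the scatter, with no direction claimed. Compound 3 is estimated at 10000 nM, ranging from 4000 nM to 30000 nM.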

Compound 3, half-maximal inhibitory concentration: 18100 nM
Compound 3: middle estimate off by 1.8-fold (0.26 log units), on the low side; the range from low to high includes it.
By their numbers in this assay, from the lowest: compounds 1 and 3 (each within the scatter of the next); then compound 2.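

Methoxy in place of hydrogen gives a 1.8-fold higher number from compound 1 to compound 3 (0.26 log units; within the scatter) in this assay, so this substitution on an aromatic carbon, para to a large group, does not separate the two compounds beyond the usual scatter. Among these compounds, this is the first measured substitution on the phenyl group, since the only earlier step changed fluoro to trifluoromethyl on the other aromatic substituent. No measured property accompanies this result that would help interpret it.

A single methoxy example leaves open whether an amine, a carboxylic acid or a longer chain such as ethoxy at the same place would give a step beyond the scatter. The compounds shown also leave open how methoxy would read out with trifluoromethyl in place of fluoro, as in compound 2.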